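The source may report more compounds than this note shows. Statements on the series, on what has been measured and on what is new or still open speak of the compounds shown alone.

Three compounds of one series carry a shared core with a basic amine on a chain bound through an oxygen on an aromatic ring. Compound 1 `O=c1cc(-c2ccccc2)oc2cccc(OCCCN3CCC(O)CC3)c12` gives 125 nM in an assay on isolated protein (Cavia porcellus) with Sigma non-opioid intracellular receptor 1 (Homo sapiens) as the target, read by radioligand binding; a higher number here means a weaker inhibitor, a lower number a stronger inhibitor. Compound 2 `O=c1cc(-c2ccccc2)oc2cccc(OCCCCCCCN3CCC(O)CC3)c12`, with a longer chain, gives 36 nM in this assay. Compound 3 `CN(C)CCCCCCCCOc1ccc2oc(-c3ccccc3)cc(=O)c2c1` gives 227 nM in this assay. The numbers for compound 3 and compound 1 lie within the scatter of each other, so nothing separates them, whereas compound 2 stands beyond the scatter at the stronger side, the only clear gap among the three.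

Compound 4 `CN(CCCCCCOc1ccc2oc(-c3ccccc3)cc(=O)c2c1)Cc1ccccc1` is the next step from compound 3: benzyl(methyl)amino in place of 2-(dimethylamino)ethyl on a saturated chain carbon, six bonds along the chain from an oxygen on an aromatic ring. Within the data shown here, no measured pair shows this change, so the expectation rests on the three numbers alone. The trend from compound 1 to compound 2 runs in the opposite direction to a shortening of the chain, and nothing shows what the benzyl group does on its own. The expected step from compound 3 to compound 4 is therefore small, a 1.9-fold lower number from compound 3 to compound 4 (0.28 log units; within the scatter), leaning toward a lower number but not surely beyond the scatter. Compound 4 is estimated at 120 nM, with a range from 30 nM to 450 nM.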

Compound 4, half-maximal inhibitory concentration: 52 nM
The estimate for compound 4 lay 2.3-fold (0.36 log units) above the measured number; low and high end bracket the measured number.
By their numbers in this assay, from the lowest: compounds 2 and 4 (each within the scatter of the next); then compounds 1 and 3 (each within the scatter of the next).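

Among these compounds, the swap of 2-(dimethylamino)ethyl for benzyl(methyl)amino, on a saturated chain carbon, six bonds along the chain from an oxygen on an aromatic ring, gives a 4.4-fold lower number from compound 3 to compound 4 (0.64 log units; beyond the scatter) in this assay, and this is the only step that can be read across one place. It shows that this position takes a six-membered aromatic ring of carbon only with a lower number rather than a higher one, which compounds 1, 2 and 3, none of which has such a ring on its amine, could not show, while the count of nitrogen atoms, hydrogen-bond donors and acceptors stays the same in both groups. Nothing in the available data gives a reason for this step.

The same difference also reads as 4-(dimethylamino)butyl to 2-(benzyl(methyl)amino)ethyl, so the benzyl group and the shorter chain remain tied together, and only a dimethylamino group on the chain of compound 4 or a benzyl(methyl)amino group on the chain of compound 3 would pull them apart. Also open, as far as these compounds go, is how a 4-hydroxypiperidine on these chains, or a phenethyl group on the amine, would compare with the benzyl group.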